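The source may hold more compounds than are shown below. What is called first, only, known or untested is meant among the compounds shown, and "the series" means these compounds.

Working notes on the series. Compound 1 `CCOC(=O)C1CCN(C(=O)CN2CN(c3ccccc3)C3(CCN(C(=O)c4ccc(C(C)(C)C)cc4)CC3)C2=O)CC1`, compound 2 `CCc1nn(CC)c(C2CCN(C(=O)CN3CN(c4ccccc4)C4(CCN(C(=O)c5ccc(C(C)(C)C)cc5)CC4)C3=O)CC2)c1CC`, compound 3 `CCc1nn(CC)c(C2CCN(C(=O)CN3CN(c4ccccc4)C4(CCN(C(=O)c5ccc(C(C)(C)C)cc5)CC4)C3=O)CC2)c1C` and the unmeasured compound 4 `CC(C)(C)c1ccc(C(=O)N2CCC3(CC2)C(=O)N(CC(=O)N2CCCC(O)C2)CN3c2ccccc2)cc1` share one core. In an assay on HEK293 cells for displacement of a labelled ligand from NPC1-like intracellular cholesterol transporter 1 (Homo sapiens) (a higher number here means a weaker inhibitor, a lower number a stronger inhibitor), compound 1 gives 3100 nM, the second highest of three numbers; compound 2 gives 4600 nM and compound 3 gives 2500 nM. Compound 4 differs from compound 1 on a carbonyl carbon: 3-hydroxypiperidin-1-yl in place of 4-(ethoxycarbonyl)piperidin-1-yl on a carbonyl carbon. For the measured compounds named here, no measured step exchanges that whole ring; the nearest guides are a 1.5-fold higher number from compound 1 to compound 2 (0.17 log units; within the scatter) and a 1.2-fold lower number from compound 1 to compound 3 (0.09 log units; within the scatter), which alter the group carried on the same ring, together with a 1.8-fold lower number from compound 2 to compound 3 (0.26 log units; within the scatter). All lie within the scatter, so no step beyond the scatter is expected for compound 4, a 1.1-fold higher number from compound 1 to compound 4 (0.05 log units; within the scatter). Compound 4 is estimated at 3500 nM, with a range of 1200 nM to 10000 nM.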

Compound 4, half-maximal inhibitory concentration: 12200 nM
Compound 4: middle estimate off by 3.5-fold (0.54 log units), on the low side; the whole stated range lies below it.
By their numbers in this assay, from the lowest: compounds 3, 1 and 2 (each within the scatter of the next); then compound 4.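

Putting 3-hydroxypiperidin-1-yl in place of 4-(ethoxycarbonyl)piperidin-1-yl on a carbonyl carbon gives a 3.9-fold higher number from compound 1 to compound 4 (0.59 log units; beyond the scatter) in this assay, the only step shown beyond the scatter, so this position does not tolerate every change. The exchange removes the ethoxycarbonyl group and adds a hydroxyl, a hydrogen-bond donor, in a single step, so the two changes cannot be separated here. No supporting data bear on the cause of this step. On these data alone, it remains open whether the loss of ethoxycarbonyl or the entry of hydroxyl carries the step. Unsubstituted piperidin-1-yl, or a carboxylic acid or an amine on that ring, would bear on this.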